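Aryl swap on the aniline nitrogen of a quinazoline-type series

This account rests on a few compounds, and the source may have more. Where it says the series, first, only, none or still open, it means among the compounds named here.

Compound 1: `CCS(=O)(=O)Nc1cc(-c2ccc3ncnc(Nc4ccc(F)cc4F)c3c2)cnc1OC` — 4010 nM
Compound 2: `CCS(=O)(=O)Nc1cc(-c2ccc3ncnc(Nc4ccc(OC)cc4)c3c2)cnc1OC` — 3490 nM

Of the compounds shown here, two of this set have been measured in a functional assay on HCT-116 cells (Homo sapiens) for cytotoxicity, read by sulforhodamine B assay, with a stated time of 72 h; on this read-out lower numbers stand for stronger inhibition and higher numbers for weaker inhibition. Compound 1 gives 4010 nM, the higher of the two numbers; compound 2 gives 3490 nM, and the step of a 1.1-fold lower number from compound 1 to compound 2 (0.06 log units; within the scatter) shows the two values to be indistinguishable within the scatter.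

The unmeasured compound 3, `CCS(=O)(=O)Nc1cc(-c2ccc3ncnc(Nc4ccc(OC)nc4)c3c2)cnc1OC`, differs from compound 1 by 6-methoxypyridin-3-yl in place of 2,4-difluorophenyl on a nitrogen on an aromatic ring. Going by the values given here, the only measured step that bears on this change is the one from compound 1 to compound 2, where a different group replaced the same 2,4-difluorophenyl on the same nitrogen and produced no movement beyond the scatter. On that basis no step beyond the scatter is expected for compound 3 in this assay, in either direction. Compound 3 is therefore estimated at 3500 nM, with a range of 1500 nM to 8000 nM, corresponding to an expected step of a 1.1-fold lower number from compound 1 to compound 3 (0.06 log units; within the scatter).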

Compound 3, half-maximal inhibitory concentration: 6910 nM
Compound 3: the middle estimate sits 2.0-fold (0.30 log units) below what was measured; the measured number falls inside the stated range.
By their numbers in this assay, from the lowest: compounds 2, 1 and 3 (each within the scatter of the next).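

In this assay, a ring with a hetero atom now stands on this nitrogen, and the swap from 2,4-difluorophenyl to 6-methoxypyridin-3-yl gives a 1.7-fold higher number from compound 1 to compound 3 (0.24 log units; within the scatter), while the swap from 4-methoxyphenyl to the same group gives a 2.0-fold higher number from compound 2 to compound 3 (0.30 log units; within the scatter). Neither step leaves the scatter, so the three groups on this nitrogen cannot be told apart in this read-out, and the change of ring type shows no effect that these numbers can resolve. No measurement bears on why the numbers of these compounds stay so close.

All three groups are six-membered aromatic rings, so the compounds shown leave open what a saturated cyclohexyl ring or an open alkyl chain would do on this nitrogen. They also leave open whether a ring carrying an amine or a carboxylic acid would move the number beyond the scatter.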